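The source may report more compounds than this note shows. Statements on the series, on what has been measured and on what is new or still open speak of the compounds shown alone.

Measured compounds in a functional assay on the whole organism (strain Fischer 344) for inhibition, with Rattus norvegicus as the target, read by paw edema, at a dose of 0.01 mmol/kg by the intraperitoneal route; a lower number here means less inhibition, a higher number more inhibition at the dose given (going by the name of the read-out):
Compound 1 `COC(=O)c1c(O)c2ccccc2n(C)c1=O` gives 58.8%.
Compound 2 `COC(=O)c1c(O)c2ccccc2n(-c2ccccc2)c1=O` gives 37.1%.
Compound 3 `Cn1c(=O)c(C(=O)NCCCCCCNC(=O)CCCCC2CCSS2)c(O)c2ccccc21` gives 53%.

Compound 4 `O=C(CCCCC1CCSS1)NCCCCCCNC(=O)c1c(O)c2ccccc2n(-c2ccccc2)c1=O` has not been measured in this assay. It is related to compound 3 by phenyl in place of methyl on an aromatic nitrogen. The same change, compound 1 to compound 2, is phenyl in place of methyl on an aromatic nitrogen. The surroundings of the changed place differ slightly: in compound 1 the nitrogen is meta to a methoxycarbonyl group, in compound 3 it is meta to a large group, so the two changes are of the same kind rather than the same. The difference between the core of compound 1 and the core of compound 3 is not broken down here. Compound 3 and compound 1 give numbers within the scatter of each other; the step from compound 3 to compound 2 is beyond it.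

Once measured, the step of a number 21.7 percentage points lower from compound 1 to compound 2 (beyond the scatter) gives a guide. The step from compound 3 to compound 4 is expected to be of similar size, a number 20 percentage points lower from compound 3 to compound 4 (beyond the scatter), resting on a number 21.7 percentage points lower from compound 1 to compound 2 (beyond the scatter). Compound 4 is therefore expected to give about 33%, likely between 18% and 48%.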

Compound 4, a percentage reported as inhibition, in the whole organism at one dose (the size of the read-out at that dose, not a potency): 50%
Compound 4: the middle estimate sits 17 percentage points below what was measured; measured number above the stated range.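

In this assay, phenyl in place of methyl on the aromatic nitrogen gives a number 3 percentage points lower from compound 3 to compound 4 (within the scatter). The change therefore does not carry over from one core to the other with the same size: the same change on two cores in this assay, a number 21.7 percentage points lower (beyond the scatter) from compound 1 to compound 2 and a number 3 percentage points lower (within the scatter) from compound 3 to compound 4, 18.7 percentage points apart, beyond the scatter of two such steps This shows that the step seen on the core of compound 1 cannot be applied as a fixed amount to the core of compound 3, but it does not show which part of the two cores sets the steps apart, and two pairs read at a single dose give no rule for any further core.

The compounds shown leave open how an ethyl or a benzyl group on the aromatic nitrogen would read on either core. They also leave open whether the step stays this small with a shorter chain in the large group of compound 3, or how it reads with a carboxylic acid in place of the methoxycarbonyl group of compound 1.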